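A few compounds are considered here, and "the series" means these few. Any claim that something is new, unique, unknown or untested is made for them only; others in the source may bear on it.

Measured compounds in the growth-inhibition read-out:

- compound 1, `Cc1cn2c(/C=N/NC(=N)N)c(-c3ccncc3)nc2s1`: 23400 nM
- compound 2, `N=C(N)N/N=C/c1c(-c2cc([N+](=O)[O-])c(Cl)cc2Cl)nc2sc(Cl)cn12`: 29500 nM
- compound 3, `N=C(N)N/N=C/c1c(-c2ccncc2)nc2sc(Cl)cn12`: 6610 nM

In a functional assay on renal cells (Homo sapiens) for antiproliferative activity (on this read-out higher numbers stand for weaker inhibition of growth and lower numbers for stronger inhibition of growth), compound 1 gives the second highest of the three numbers. Compound 2 lies within the scatter of it; compound 3 lies clearly below it. Among the measured compounds shown here, the only single-point step measured so far is a 3.5-fold lower number from compound 1 to compound 3 (0.55 log units; beyond the scatter), a change of the substituent on the fused core and not of the aryl group.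

Compound 4, `Cc1cn2c(/C=N/NC(=N)N)c(-c3ccccn3)nc2s1`, differs from compound 1 by pyridin-2-yl in place of pyridin-4-yl on an aromatic carbon. For the measured compounds named here, none of the measured steps bears on this position: the step from compound 1 to compound 3 alters a different place, and compound 2 differs from compound 1 at two places at once, so that pair gives no clean reading either. With nothing in the series to point either way, the expectation for this assay is a step no larger than the scatter. The estimated step is a 1.0-fold lower number from compound 1 to compound 4 (0.01 log units; within the scatter), which is meant as no clear change. Compound 4 is therefore expected to give 23000 nM, with a range from 7000 nM to 75000 nM, the width reflecting the absence of any comparable measured step.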

Compound 4, concentration for 50% growth inhibition: 7940 nM
Compound 4: the middle estimate sits 2.9-fold (0.46 log units) above what was measured, within the range that was stated.
By their numbers in this assay, from the lowest: compounds 3 and 4 (each within the scatter of the next); then compounds 1 and 2 (each within the scatter of the next).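

In this assay, this position on the aromatic carbon of the shared core responds to where the pyridine is attached: pyridin-2-yl in place of pyridin-4-yl gives a 2.9-fold lower number from compound 1 to compound 4 (0.47 log units; beyond the scatter). The earlier compounds shown here gave no clean reading at this position, and this modest step now shows that it is not silent, even though the two groups have the same atoms and the same counts of donors and acceptors. No measurement at hand accounts for the difference between the two attachments.

The compounds shown leave open how pyridin-3-yl or a plain phenyl would read at this position, and whether an amine on the pyridin-2-yl ring would shift the number. Also open, as far as these compounds go, is whether pyridin-2-yl and chloro on the core, taken together, would add up.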